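Acetoxy on the benzoate ring: compound 3 to compound 4

The source may report more compounds than this note shows. Statements on the series, on what has been measured and on what is new or still open speak of the compounds shown alone.

Compound 3 `O=C(OC1(C(=O)Nc2ccc([N+](=O)[O-])cc2)CCCCC1)c1ccccc1` gives 766 nM in a functional assay on NFS-60 cells (Mus musculus) for inhibition, read by MTT assay, with a stated time of 72 h (on this read-out higher numbers stand for weaker inhibition and lower numbers for stronger inhibition), the highest of the three numbers measured: compound 1 `O=C(OC1(C(=O)Nc2ccc([N+](=O)[O-])cc2)CCCCC1)c1ccc(Br)cc1` gives 236 nM and compound 2 `O=C(/C=C/c1ccccc1)OC1(C(=O)Nc2ccc([N+](=O)[O-])cc2)CCCCC1` gives 50.5 nM. The step to compound 4 `CC(=O)Oc1ccccc1C(=O)OC1(C(=O)Nc2ccc([N+](=O)[O-])cc2)CCCCC1` is acetoxy in place of hydrogen on an aromatic carbon. Going by the values given here, the one measured step on that aromatic ring is a 3.2-fold higher number from compound 1 to compound 3 (0.51 log units; beyond the scatter); read in reverse, it shows a ring substituent going with a lower number. The steps of a 4.7-fold lower number from compound 1 to compound 2 (0.67 log units; beyond the scatter) and a 15-fold higher number from compound 2 to compound 3 (1.18 log units; beyond the scatter) replace the whole acyl group and bear less directly. A modest lowering is therefore expected in this assay, with wide uncertainty since group and place differ from the bromo case. Compound 4 is estimated at 350 nM, range 100 nM to 1200 nM, an expected step of a 2.2-fold lower number from compound 3 to compound 4 (0.34 log units; beyond the scatter).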

Compound 4, half-maximal inhibitory concentration: 11.3 nM
Compound 4: middle estimate off by 31-fold (1.49 log units), on the high side; measured number below the stated range.
By their numbers in this assay, from the lowest: compound 4; then compound 2; then compound 1; then compound 3.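

In this assay, acetoxy ortho to a large group gives the largest step in the series, a 68-fold lower number from compound 3 to compound 4 (1.83 log units; beyond the scatter). The 2-acetoxyphenyl group also goes beyond both other replacements of the phenyl group, with a 4.5-fold lower number from compound 2 to compound 4 (0.65 log units; beyond the scatter) and a 21-fold lower number from compound 1 to compound 4 (1.32 log units; beyond the scatter). No measurement available here explains the size of these steps.

Still open, as far as these compounds go, is whether this lowering needs acetoxy itself or would also follow from another group in that place. Hydroxy, methoxy or acetamido there would separate these readings.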